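Trifluoromethoxy for trifluoromethyl on a shared core

This account rests on a few compounds, and the source may have more. Where it says the series, first, only, none or still open, it means among the compounds named here.

Compound 1, `Oc1ccccc1-c1cc(-c2cccc(C(F)(F)F)c2)cc(-c2ccccc2O)n1`: in a functional assay on HCT-15 cells (Homo sapiens) for inhibition (a higher number here means a weaker inhibitor, a lower number a stronger inhibitor), compound 1 gives only a limit, > 50000 nM.
Compound 2, `Oc1ccccc1-c1cc(-c2ccc(C(F)(F)F)cc2)cc(-c2ccccc2O)n1`: in this assay compound 2 gives only a limit, > 50000 nM.
Compound 3, `Oc1ccccc1-c1cc(-c2cccc(OC(F)(F)F)c2)cc(-c2ccccc2O)n1`: in this assay compound 3 gives only a limit, > 50000 nM.

Compound 2 differs from compound 1 in one place: 4-(trifluoromethyl)phenyl in place of 3-(trifluoromethyl)phenyl on an aromatic carbon. The step that the two limits leave unreadable from compound 1 to compound 2 cannot be read, since both compounds are reported only as a limit. Compound 3 differs from compound 1 by trifluoromethoxy in place of trifluoromethyl on an aromatic carbon, and here too the step that the two limits leave unreadable from compound 1 to compound 3 is not readable. What the three share is that every value sits at the limit of > 50000 nM in this assay, at which 3 of the 3 values shown sit, so none of them shows measurable inhibition within the range of this assay.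

Compound 4, `Oc1ccccc1-c1cc(-c2ccc(OC(F)(F)F)cc2)cc(-c2ccccc2O)n1`, has not yet been measured. It differs from compound 2 by trifluoromethoxy in place of trifluoromethyl on an aromatic carbon. Among the measured compounds shown here, this is the same kind of change as the one from compound 1 to compound 3, but not the same: in compound 3 the trifluoromethoxy stands meta to a large group, whereas in compound 4 it stands para to a large group.

Because all three measured compounds sit at the limit of > 50000 nM in this assay, at which 3 of the 3 values shown sit, compound 4 is expected to behave alike, and the step that the limit leaves unreadable from compound 2 to compound 4 is expected to be small. The estimate for compound 4 in this assay is 100000 nM, with a range from 30000 nM to 500000 nM, and most likely the assay will again report only a limit.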

Compound 4, half-maximal inhibitory concentration: > 50000 nM
Compound 4: a limit, no number (the forecaster's own chance of this, stated with the estimate: 90%); the middle value does not contradict the limit.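

Compound 4, like compound 2, is reported in this assay only as a limit, so no step can be read between compound 2 and compound 4, nor between the other pairs. All the values shown stand at the same limit: the limit of > 50000 nM in this assay, at which 4 of the 4 values shown sit. The compounds shown leave open how strongly any of these four compounds inhibits, and whether any difference separates them in this assay.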